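The source may report more compounds than this note shows. Statements on the series, on what has been measured and on what is new or still open speak of the compounds shown alone.

Measured so far in an ADME assay on A549 cells (Homo sapiens) for cytotoxicity, read by CellTiter-Glo; on this read-out lower numbers stand for higher toxicity in this test and higher numbers for lower toxicity in this test:
Compound 1 `C#CCNCC(O)COc1ccc2c(C)c(Cc3ccccc3)c(=O)oc2c1`: 95500 nM
Compound 2 `Cc1c(Cc2ccccc2)c(=O)oc2cc(OCC(O)CNc3cc([N+](=O)[O-])ccc3O)ccc12`: > 100000 nM, a limit
Compound 3 `Cc1c(Cc2ccccc2)c(=O)oc2cc(OCC(O)CNCc3ccccc3)ccc12`: > 100000 nM, a limit

Compound 3 has no exact number, as its > 100000 nM is a limit of the assay. That mark is the limit of > 100000 nM in this assay, at which 2 of the 3 values shown sit.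

The move to compound 4 `Cc1c(Cc2ccccc2)c(=O)oc2cc(OCC(O)CNCCCO)ccc12` is 2-hydroxyethyl in place of phenyl on a saturated chain carbon bound to an amine nitrogen. It places 2-hydroxyethyl in place of phenyl on a saturated chain carbon bound to an amine nitrogen, which, cut one bond further out, reads benzyl to 3-hydroxypropyl.

The measured step closest to this change concerns the same place: an at least 1.0-fold higher number from compound 1 to compound 3 (0.01 log units; that floor lies within the scatter). It swaps phenyl for ethynyl, and its floor lies within the scatter. The step of an at least 1.0-fold higher number from compound 1 to compound 2 (0.01 log units; that floor lies within the scatter) also has a floor within the scatter, while a step that the two limits leave unreadable from compound 2 to compound 3 gives no size at all.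

Compound 1, which lacks the phenyl at this place, still gives 95500 nM, so removing that ring is not expected to move the value much in this assay. The expected size is a number no higher from compound 3 to compound 4 (the limit leaves the size open), which means no step beyond the scatter. Compound 4 is estimated at 100000 nM, with an expected range from 45000 nM to 200000 nM, and the assay may well report only a limit.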

Compound 4, half-maximal cytotoxic concentration: 53400 nM
Beside the measured number, compound 4's estimate is 1.9-fold (0.27 log units) above it; the measured number falls inside the stated range.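

In this assay the 3-hydroxypropyl group on the amine nitrogen gives a readable number where the benzyl group gave only a limit (an at least 1.8-fold lower number from compound 3 to compound 4 (0.27 log units; that floor lies within the scatter)), and the same holds against the 2-hydroxy-5-nitrophenyl group (an at least 1.8-fold lower number from compound 2 to compound 4 (0.27 log units; that floor lies within the scatter)). Both steps are floors within the scatter, which shows no real drop and leaves their true size unsettled on the side of the limit: (the limit of > 100000 nM in this assay, at which 2 of the 4 values shown sit). The propargyl and 3-hydroxypropyl chains on this nitrogen read alike (a 1.8-fold lower number from compound 1 to compound 4 (0.25 log units; within the scatter)), and among the compounds shown the two open chains carry exact numbers while the two groups holding an aromatic ring sit at the limit, with no compound going against that.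

The compounds shown leave open whether the hydroxyl of the 3-hydroxypropyl group counts for anything, a question that a plain propyl group on the same nitrogen would speak to. They also do not tell how a longer chain, or a chain ending in an amine or a carboxylic acid, would read in this assay at this place.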